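The compounds below may be only part of what the source reports. "The series", "measured", "known", "first", "only" and "open" are said of these compounds alone.

Measured so far in an ADME assay on a cell-free system (plasma, Homo sapiens) for metabolic stability, with Plasma (Rattus norvegicus) as the target, read by HPLC, at pH 7.4; on this read-out lower numbers stand for a shorter-lived compound and higher numbers for a longer-lived compound:
- compound 1, `CC(=O)Oc1ccccc1C(=O)O[C@H]1CO[C@H]2[C@@H]1OC[C@H]2OC(=O)c1ccc(O)cc1`, 0.0198 h
- compound 2, `CC(=O)Oc1ccccc1C(=O)O[C@H]1CO[C@H]2[C@@H]1OC[C@H]2OC(C)=O`, 0.0095 h
- compound 3, `CC(=O)Oc1ccccc1C(=O)O[C@H]1CO[C@H]2[C@@H]1OC[C@H]2OC(=O)c1cccc(C)c1`, 0.0203 h

Compound 2 stands lowest of the three numbers, so it is the shortest-lived of these compounds in this assay. Compound 4, `CC(=O)Oc1ccccc1C(=O)O[C@H]1CO[C@H]2[C@@H]1OC[C@H]2OC(=O)c1ccc(-c2ccccc2)cc1`, differs from it in one place: 4-phenylphenyl in place of methyl on a carbonyl carbon. Going by the values given here, two measured steps bear on this, both replacing the same methyl with an aromatic ring: a 2.1-fold lower number from compound 1 to compound 2 (0.32 log units; beyond the scatter), and a 2.1-fold higher number from compound 2 to compound 3 (0.33 log units; beyond the scatter). Both aryl-for-methyl swaps moved the number up by a modest, similar amount, and 4-phenylphenyl is another aromatic ring at the same carbonyl carbon. A modest rise is therefore expected, a 2.2-fold higher number from compound 2 to compound 4 (0.34 log units; beyond the scatter). Compound 4 is estimated at 0.021 h, with a range from 0.009 h to 0.05 h.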

Compound 4, half-life: > 0.333 h
Compound 4 gave a limit, no number (the forecaster's own chance of this, stated with the estimate: 5%); middle value at least 15-fold (1.20 log units) away from the limit.
By their numbers in this assay, from the lowest: compound 2; then compounds 1 and 3 (each within the scatter of the next). At a limit, above all of these: compound 4.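

Compound 4 gave a limit, not a number, in this assay: the limit of > 0.333 h in this assay, at which 1 of the 4 values shown sits. Going by these compounds alone, at this carbonyl carbon, the single aromatic rings of compounds 1 and 3 gave only modest steps over methyl, yet 4-phenylphenyl gives an at least 35-fold higher number from compound 2 to compound 4 (1.54 log units; beyond the scatter) as the step over methyl. The size of the group on this carbonyl therefore matters, not just the presence of an aromatic ring, as an at least 16-fold higher number from compound 3 to compound 4 (1.21 log units; beyond the scatter) and an at least 16-fold higher number from compound 1 to compound 4 (1.22 log units; beyond the scatter) also show.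

As far as these compounds go, it remains open whether a second ring is needed, or whether a longer chain such as octyl would do the same here. An amine or a carboxylic acid on the outer ring of 4-phenylphenyl is also untested in the compounds shown.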